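Dimethylamino to diethylamino on the amide side chain

The source may report more compounds than this note shows. Statements on the series, on what has been measured and on what is new or still open speak of the compounds shown alone.

Measured compounds:
compound 1, `CCN(CC)CCNC(=O)c1ccc(C(CC)(CC)c2ccc(OCC(=O)C(C)(C)C)c(C)c2)n1CC`, 91 nM
compound 2, `CCn1c(C(=O)NCCN(C)C)ccc1C(CC)(CC)c1ccc(OCC(=O)C(C)(C)C)c(C)c1`, 77 nM
compound 3, `CCn1c(C(=O)NCCCN(C)C)ccc1C(CC)(CC)c1ccc(OCC(O)C(C)(C)C)c(C)c1`, 37 nM

In an assay on HL-60 cells for agonist activity at vitamin D3 receptor (Homo sapiens), read by microscopy, with a stated time of 96 h (a lower number here means that less compound is needed, a higher number that more compound is needed for the effect), compound 2 gives 77 nM and compound 1 gives 91 nM. The two differ by diethylamino in place of dimethylamino on a saturated chain carbon, two bonds along the chain from an amide-type nitrogen, and the step is a 1.2-fold higher number from compound 2 to compound 1 (0.07 log units; within the scatter), so the two numbers cannot be told apart by this assay. Compound 3 gives 37 nM in this assay, the lowest of the three numbers, with both other compounds beyond the scatter above it. The difference between the core of compound 2 and the core of compound 3 is not broken down here.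

Compound 4, `CCN(CC)CCCNC(=O)c1ccc(C(CC)(CC)c2ccc(OCC(O)C(C)(C)C)c(C)c2)n1CC`, has not been measured in this assay. It differs from compound 3 by diethylamino in place of dimethylamino on a saturated chain carbon, three bonds along the chain from an amide-type nitrogen. For the measured compounds named here, this is the same kind of change as the one from compound 2 to compound 1, not the same: there the place was two bonds along the chain from an amide-type nitrogen, here it is three bonds along the chain from an amide-type nitrogen. Going by the values given here, only one measured example of the change is available, and the pattern rests on that single pair.

The expected step is a 1.1-fold higher number from compound 3 to compound 4 (0.06 log units; within the scatter), beside the earlier one, because compound 1 against compound 2 showed a 1.2-fold higher number from compound 2 to compound 1 (0.07 log units; within the scatter) within the scatter. Compound 4 is therefore estimated at 42 nM in this assay, with an expected range from 20 nM to 90 nM.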

Compound 4, half-maximal effective concentration: 66 nM
Compound 4: middle estimate off by 1.6-fold (0.20 log units), on the low side; measured number inside the range.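

In this assay, diethylamino in place of dimethylamino gives a 1.8-fold higher number from compound 3 to compound 4 (0.25 log units; within the scatter), and this step can be set against the same change on the other core: the same change on two cores in this assay, a 1.2-fold higher number (0.07 log units; within the scatter) from compound 2 to compound 1 and a 1.8-fold higher number (0.25 log units; within the scatter) from compound 3 to compound 4, 1.5-fold (0.18 log units) apart, within the scatter of two such steps. Within these two pairs, then, the change carries from one core to the other without a step that this assay can separate from the scatter, and neither pair gives a measurable difference between the dimethylamino and diethylamino compounds. This does not show that the two steps are identical or that the change would behave alike on further cores, and the two pairs also differ in its place, two bonds along the chain from an amide-type nitrogen in one and three bonds in the other, so any contribution of the core cannot be separated from that of the place.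

The compounds shown leave open whether a cyclic amine such as pyrrolidine, piperidine or morpholine, a primary amine, or a longer chain would fit the same pattern at this end of the side chain. They also leave open how the ketone and the secondary alcohol compare on a single chain length, with the amine held constant.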